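From Chloro to Bromo: A Small Expected Step

The source may hold more compounds than are shown below. What is called first, only, known or untested is meant among the compounds shown, and "the series" means these compounds.

In a functional assay on MCF7 cells (Homo sapiens) for antiproliferative activity, read by MTT assay, with a stated time of 48 h (a lower number here means a stronger inhibitor, a higher number a weaker inhibitor), compound 1 `O=[N+]([O-])c1cc(C(F)(F)F)cc([N+](=O)[O-])c1Oc1ccccc1/C=N\OCc1ccccc1` gives 1330 nM. Compound 2 `O=[N+]([O-])c1cc(C(F)(F)F)cc([N+](=O)[O-])c1Oc1ccc(Cl)cc1/C=N\OCc1ccccc1` gives 1220 nM, and compound 3 `O=[N+]([O-])c1cc(C(F)(F)F)cc([N+](=O)[O-])c1Oc1ccc(Cl)cc1/C=N\OCc1ccccc1Cl` gives 3950 nM. Compound 2 therefore stands at the low end of these numbers, level with compound 1 within the scatter, while compound 3 lies clearly higher.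

Compound 4 `O=[N+]([O-])c1cc(C(F)(F)F)cc([N+](=O)[O-])c1Oc1ccc(Br)cc1/C=N\OCc1ccccc1` differs from compound 2 in one place: bromo in place of chloro on an aromatic carbon. This is bromo in place of chloro on an aromatic carbon. Among the compounds with values here, no measured step shows this exact swap, but two steps with chloro in place of hydrogen offer some guidance. At the carbon that changes here, the measured result is a 1.1-fold lower number from compound 1 to compound 2 (0.04 log units; within the scatter). Elsewhere in the molecule, the same kind of change gives a 3.2-fold higher number from compound 2 to compound 3 (0.51 log units; beyond the scatter), which is a modest rise and a less direct guide. The closer precedent suggests that a change at this carbon may matter little. The expected result is a 1.1-fold higher number from compound 2 to compound 4 (0.03 log units; within the scatter), with no change beyond the scatter. For compound 4, the estimated value is 1300 nM, with an expected range of 650 nM to 2600 nM.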

Compound 4, half-maximal inhibitory concentration: 1150 nM
Compound 4: middle estimate off by 1.1-fold (0.05 log units), on the high side; the range from low to high includes it.
By their numbers in this assay, from the lowest: compounds 4, 2 and 1 (each within the scatter of the next); then compound 3.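

In this assay, bromo in place of chloro on this aromatic carbon leaves the result level (a 1.1-fold lower number from compound 2 to compound 4 (0.03 log units; within the scatter)), and bromo in place of hydrogen does the same (a 1.2-fold lower number from compound 1 to compound 4 (0.06 log units; within the scatter)). This carbon has now carried hydrogen, chloro and bromo without the assay telling them apart, so the flat result seen for chloro alone extends to a second halogen. Nothing available here explains this flat result.

Going by these compounds, whether the carbon stays this undemanding for groups of another kind, such as an amine, a carboxylic acid or a longer chain, remains open. Also open, on these data alone, is whether compound 4 would respond as compound 2 did to the added chloro that gives compound 3.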